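A Carboxy Group Replaces the 4-Fluorophenyl Arm

This account rests on a few compounds, and the source may have more. Where it says the series, first, only, none or still open, it means among the compounds named here.

Three compounds built on a shared core were tested in an assay on isolated protein for inhibition of 2-Hydroxyacid oxidase 2 (Homo sapiens), tested at 1 uM; a higher number here means a stronger effect of the compound at the concentration tested, a lower number a weaker effect. Compound 1 `Cc1n[nH]c(C(=O)O)c1Cc1ccc(C(F)(F)F)cc1` gives 9%, compound 2 `Cc1n[nH]c(C(=O)O)c1Cc1ccc(Oc2ccccc2)cc1` gives 10%, and compound 3 `Cc1n[nH]c(C(=O)O)c1Cc1ccc(-c2ccc(F)cc2)cc1` gives 11%. Compound 3 holds the highest of the three numbers, yet all three sit within the scatter of one another, so no order among them can be claimed. The steps of a number 1 percentage points higher from compound 1 to compound 2 (within the scatter), a number 2 percentage points higher from compound 1 to compound 3 (within the scatter) and a number 1 percentage points higher from compound 2 to compound 3 (within the scatter) were all small. Compound 4 `Cc1n[nH]c(C(=O)O)c1Cc1ccc(C(=O)O)cc1` differs from compound 3 in one place: carboxy in place of 4-fluorophenyl on an aromatic carbon. Within the data shown here, no measured step exchanges an aromatic group for a carboxy, so none bears directly on this change, and every step seen so far stayed within the scatter. Compound 4 is therefore expected to show a number 1 percentage points lower from compound 3 to compound 4 (within the scatter), no step beyond the scatter. Compound 4 is estimated at 10%, with a range from 0% to 25%.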

Compound 4, a percentage reported as inhibition, at one concentration (the size of the read-out at that concentration, not a potency): 3%
Beside the measured number, compound 4's estimate is 7 percentage points above it, and the stated range covers the measured number.
By their numbers in this assay, from the lowest: compounds 4, 1, 2 and 3 (each within the scatter of the next).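

Placed on this aromatic carbon in this assay, carboxy in place of 4-fluorophenyl gives a number 8 percentage points lower from compound 3 to compound 4 (within the scatter) and, against the other two groups, a number 7 percentage points lower from compound 2 to compound 4 (within the scatter) and a number 6 percentage points lower from compound 1 to compound 4 (within the scatter) with no step standing out. Even trading an aromatic ring for a group with no ring and with a hydrogen-bond donor therefore leaves all four compounds indistinguishable at this position. Nothing available offers an explanation for these readings.

From the compounds shown here alone, whether an amine or a longer chain here could move the reading beyond the scatter remains open. So does whether any group at this position matters in this assay.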